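The source may report more compounds than this note shows. Statements on the series, on what has been measured and on what is new or still open speak of the compounds shown alone.

Measured compounds in a functional assay on MIA PaCa-2 cells (Homo sapiens) for inhibition, read by MTT assay, with a stated time of 3 days; a lower number here means a stronger inhibitor, a higher number a weaker inhibitor:
compound 1 `O=C([C@@H]1CCCN(S(=O)(=O)c2ccc(S(=O)(=O)N3CC[C@@H](O)C3)cc2)C1)N1CCC(F)(F)CC1` gives 135 nM;
compound 2 `CC(C)S(=O)(=O)c1ccc(S(=O)(=O)N2CCC[C@@H](C(=O)N3CCC(F)(F)CC3)C2)cc1` gives 9.1 nM;
compound 3 `CCN(CC)S(=O)(=O)c1ccc(S(=O)(=O)N2CCC[C@@H](C(=O)N[C@H]3CCOC3)C2)cc1` gives 290 nM.

Compound 3 has the highest number of the three, so it is the weakest inhibitor shown; compound 1 comes nearest, and compound 2 lies furthest away. Compound 4 `CCN(CC)S(=O)(=O)c1ccc(S(=O)(=O)N2CCC[C@@H](C(=O)N3CC[C@H](OC)C3)C2)cc1` differs from compound 3 in one place: 3-methoxypyrrolidin-1-yl in place of (oxolan-3-yl)amino on a carbonyl carbon. Among the compounds with values here, the only measured step, a 15-fold lower number from compound 1 to compound 2 (1.17 log units; beyond the scatter), changes the group on the sulfonyl sulfur, not the amide end, so it does not speak to this change; no measured pair isolates the amide side. Without a guiding step, compound 4 is expected to show a step of a 1.9-fold lower number from compound 3 to compound 4 (0.29 log units; within the scatter), that is, no clear change beyond the scatter. Compound 4 is estimated at 150 nM, within a range of 40 nM to 600 nM.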

Compound 4, half-maximal inhibitory concentration: 460 nM
The estimate for compound 4 lay 3.1-fold (0.49 log units) below the measured number, within the range that was stated.
By their numbers in this assay, from the lowest: compound 2; then compound 1; then compounds 3 and 4 (each within the scatter of the next).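

Measured in this assay the amide end now has its first step: 3-methoxypyrrolidin-1-yl in place of (oxolan-3-yl)amino gives a 1.6-fold higher number from compound 3 to compound 4 (0.20 log units; within the scatter) on a carbonyl carbon. The change goes from 1 hydrogen-bond donor to 0 hydrogen-bond donors, yet compound 3 and compound 4 remain indistinguishable here, so this donor shows no measurable role in this pair. No supporting data offer an explanation for this result. Still open, as far as these compounds go, is whether a morpholine or a dimethylamino group on that carbonyl carbon would read differently. The same question applies to either swap when isopropyl sits on the sulfonyl sulfur.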